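The source may hold more compounds than are shown below. What is called first, only, known or untested is meant among the compounds shown, and "the series" means these compounds.

Among the compounds with values here, in a functional assay on HepG2 cells (Homo sapiens) for antiproliferative activity, read by CCK-8 assay, with a stated time of 48 h (a lower number here means a stronger inhibitor, a higher number a weaker inhibitor), compound 1 `COc1ccc(/C=C\c2cc(OC)c(OC)c(OC)c2)cc1OCc1ccc(CO)cc1` gives 2400 nM and compound 2 `COc1ccc(/C=C\c2cc(OC)c(OC)c(OC)c2)cc1OCc1ccc(CN2CC[C@@H](C(=O)O)C2)cc1` gives 2300 nM, so compound 2 stands level with the only other measured compound. Their step, a 1.0-fold lower number from compound 1 to compound 2 (0.02 log units; within the scatter), put 3-carboxypyrrolidin-1-yl in place of hydroxy on a saturated chain carbon bound to an aromatic carbon. Compound 3 `COc1ccc(/C=C\c2cc(OC)c(OC)c(OC)c2)cc1OCc1ccc(CN2CC[C@@H](O)C2)cc1` has hydroxy in place of carboxy on a saturated ring carbon. Within the data shown here, only that one step bears on this change, and it does not test the new group directly. The expected change is therefore none beyond the scatter, an estimated 1.0-fold lower number from compound 2 to compound 3 (0.02 log units; within the scatter). For compound 3 the estimate is 2200 nM, with an expected range of 900 nM to 5500 nM.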

Compound 3, half-maximal inhibitory concentration: 6200 nM
Compound 3: middle estimate off by 2.8-fold (0.45 log units), on the low side; the whole stated range lies below it.
By their numbers in this assay, from the lowest: compounds 2 and 1 (each within the scatter of the next); then compound 3.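

In this assay this ring carbon proves sensitive to its group: hydroxy in place of carboxy weakens the compound modestly (a 2.7-fold higher number from compound 2 to compound 3 (0.43 log units; beyond the scatter)). 3-Hydroxypyrrolidin-1-yl in place of the hydroxy on the saturated chain carbon also gives a modest rise (a 2.6-fold higher number from compound 1 to compound 3 (0.41 log units; beyond the scatter)), whereas 3-carboxypyrrolidin-1-yl left the number level, so the ring alone does not keep the number level. Nothing measured here explains this difference. Going by these compounds, whether a primary amide or a methyl ester on this ring carbon would behave like carboxy or like hydroxy remains open.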